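This account rests on a few compounds, and the source may have more. Where it says the series, first, only, none or still open, it means among the compounds named here.

Measured compounds:
compound 1 `Clc1cccc(Cn2cc(COc3ccccc3)nn2)c1`: > 100 ug/mL
compound 2 `Cc1ccc(OCc2cn(Cc3cccc(Cl)c3)nn2)cc1`: > 100 ug/mL
compound 3 `O=[N+]([O-])c1ccc(Cn2cc(COc3ccc(Cl)cc3)nn2)cc1`: > 100 ug/mL

In an ADME assay on PANC-1 cells (Homo sapiens) for inhibition, read by MTT assay, with a stated time of 48 h (on this read-out lower numbers stand for stronger inhibition of growth and higher numbers for weaker inhibition of growth), compound 1 gives > 100 ug/mL, which is a limit of the assay and not a number. Compound 2 gives > 100 ug/mL, likewise a limit. Compound 3 gives > 100 ug/mL, also a limit. The change from compound 1 to compound 2 is methyl in place of hydrogen on an aromatic carbon, and the step that the two limits leave unreadable from compound 1 to compound 2 cannot be sized, because of the limit of > 100 ug/mL in this assay, at which 3 of the 3 values shown sit. The difference between the cores of compound 1 and compound 3 is not broken down here. Compound 4 `Cc1cc(OCc2cn(Cc3ccc([N+](=O)[O-])cc3)nn2)ccc1Cl` is not yet measured; it differs from compound 3 by methyl in place of hydrogen on an aromatic carbon. This is the same kind of change as that from compound 1 to compound 2, though here the entering methyl sits ortho to a chloro group and meta to a large group rather than para to a large group. The step that the limit leaves unreadable from compound 3 to compound 4 is expected to be modest, because a step that the two limits leave unreadable from compound 1 to compound 2 was itself left unreadable. Compound 4 is therefore expected to give about 150 ug/mL, most likely between 60 ug/mL and 400 ug/mL.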

Compound 4, concentration for 50% growth inhibition: > 100 ug/mL
Compound 4: only a limit was reported; the forecaster's own chance of this, stated with the estimate: 85%; the middle value is on the limit's open side.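

The step from compound 3 to compound 4 cannot be read, since both values are limits and not numbers: the limit of > 100 ug/mL in this assay, at which 4 of the 4 values shown sit. The compounds shown leave open how strongly any of them inhibits growth, and what methyl in place of hydrogen on an aromatic carbon does to that.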